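A few compounds are considered here, and "the series" means these few. Any claim that something is new, unique, unknown or untested is made for them only; others in the source may bear on it.

Compound 3 `COc1ccc2cc(C(C)c3nnc4n3N=C(c3ccc(C(F)(F)F)cc3)CS4)ccc2c1` stands second highest of the three numbers in a functional assay on Huh-7 cells (Homo sapiens) for inhibition, read by sulforhodamine B assay, with a stated time of 72 h (on this read-out lower numbers stand for stronger inhibition and higher numbers for weaker inhibition), though both gaps are within the scatter; compound 3 gives 14800 nM, while compound 1 `COc1ccc2cc(C(C)c3nnc4n3N=C(c3ccc([N+](=O)[O-])cc3)CS4)ccc2c1` gives 14700 nM and compound 2 `COc1ccc2cc(C(C)c3nnc4n3N=C(c3ccc(OC(F)(F)F)cc3)CS4)ccc2c1` gives 16000 nM. Compound 4 `COc1ccc2cc(C(C)c3nnc4n3N=C(c3ccc(C)cc3)CS4)ccc2c1` differs from compound 3 by methyl in place of trifluoromethyl on an aromatic carbon. The measured steps all exchange the group at that same aromatic carbon: a 1.0-fold higher number from compound 1 to compound 3 (0.00 log units; within the scatter), a 1.1-fold higher number from compound 1 to compound 2 (0.04 log units; within the scatter) and a 1.1-fold lower number from compound 2 to compound 3 (0.03 log units; within the scatter). None of them puts methyl in place of trifluoromethyl, but nitro, trifluoromethoxy and trifluoromethyl gave numbers that cannot be told apart, so no step beyond the scatter is expected in this assay. Compound 4 is therefore expected at 15000 nM, between 7500 nM and 30000 nM, an estimated step of a 1.0-fold higher number from compound 3 to compound 4 (0.01 log units; within the scatter).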

Compound 4, half-maximal inhibitory concentration: 8200 nM
For compound 4 the middle estimate is 1.8-fold (0.26 log units) above the measured one; the measured number falls inside the stated range.
By their numbers in this assay, from the lowest: compounds 4, 1, 3 and 2 (each within the scatter of the next).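

In this assay, methyl at this aromatic carbon stays within the scatter of all three earlier groups: a 1.8-fold lower number from compound 3 to compound 4 (0.26 log units; within the scatter), a 2.0-fold lower number from compound 2 to compound 4 (0.29 log units; within the scatter) and a 1.8-fold lower number from compound 1 to compound 4 (0.25 log units; within the scatter). Among these compounds, these steps are larger than those among the earlier compounds, yet the position still shows no step beyond the scatter, now across a group without fluorine or nitro as well. Nothing available explains these numbers. As far as these compounds go, it remains open whether an amine, a carboxylic acid or a longer alkyl chain at this carbon would give a step beyond the scatter.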